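Trading ethyl for methyl in a small series

The source may hold more compounds than are shown below. What is called first, only, known or untested is meant among the compounds shown, and "the series" means these compounds.

For the measured compounds named here, in a functional assay (aorta) for inhibition, with Rattus norvegicus as the target (a lower number here means a stronger inhibitor, a higher number a weaker inhibitor), compound 3 (`CCc1nsc(-c2ccc(N3CCN(c4cccc(C(F)(F)F)c4)CC3)nn2)n1`) gives 8 nM, the second highest of the three numbers so far. Compound 2 (`FC(F)(F)c1cccc(N2CCN(c3ccc(-c4ncns4)nn3)CC2)c1`) stands higher at 70 nM, and compound 1 (`Cc1nsc(-c2ccc(N3CCN(c4cccc(Cl)c4)CC3)nn2)n1`) stands lower at 0.6 nM.

The unmeasured compound 4 (`Cc1nsc(-c2ccc(N3CCN(c4cccc(C(F)(F)F)c4)CC3)nn2)n1`) differs from compound 3 in one place: 3-ethyl-1,2,4-thiadiazol-5-yl becomes 3-methyl-1,2,4-thiadiazol-5-yl, with hydrogen in place of methyl on a saturated chain carbon bound to an aromatic carbon.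

Going by the values given here, only one measured step bears on this change. Ethyl in place of hydrogen on an aromatic carbon gave an 8.8-fold lower number from compound 2 to compound 3 (0.94 log units; beyond the scatter), a modest step beyond the scatter. That step installs the whole ethyl group, whereas compound 4 keeps a methyl on the same aromatic carbon, so a much smaller step is expected here. Among the compounds with values here, compound 1 also carries 3-methyl-1,2,4-thiadiazol-5-yl and gives 0.6 nM, but the series holds no measured step from ethyl to methyl. That value therefore only tilts the expectation slightly towards a lower number.

The expected change is a 1.6-fold lower number from compound 3 to compound 4 (0.20 log units; within the scatter), which is not expected to exceed the scatter. Compound 4 is estimated at 5 nM, with an expected range from 1.5 nM to 20 nM.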

Compound 4, half-maximal inhibitory concentration: 0.3 nM
Compound 4: middle estimate off by 17-fold (1.22 log units), on the high side, outside the stated range (below it).
By their numbers in this assay, from the lowest: compounds 4 and 1 (each within the scatter of the next); then compound 3; then compound 2.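

For the compounds shown here, the change from ethyl to methyl proves far from minor in this assay: removing one carbon gives a 27-fold lower number from compound 3 to compound 4 (1.43 log units; beyond the scatter), a step that the earlier compounds gave no means of sizing. Set beside an 8.8-fold lower number from compound 2 to compound 3 (0.94 log units; beyond the scatter) and a 230-fold lower number from compound 2 to compound 4 (2.37 log units; beyond the scatter), it shows that the number does not fall steadily as the group on this aromatic carbon grows, since hydrogen gives the highest number, ethyl an intermediate one and methyl the lowest of the three. With methyl held in place, trifluoromethyl in place of chloro gives a 2.0-fold lower number from compound 1 to compound 4 (0.30 log units; within the scatter), so compound 1 and compound 4 cannot be told apart in this assay, and the low number seen for compound 1 is not confined to the chloro compound.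

Nothing in the data given accounts for why a single carbon at this position matters so much. The compounds shown also leave open how a cyclopropyl group, a methoxy group or a longer chain such as propyl would behave on this aromatic carbon, and whether the ethyl-to-methyl step would be as large in the chloro compounds.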